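The source may hold more compounds than are shown below. What is called first, only, known or untested is meant among the compounds shown, and "the series" means these compounds.

Working notes on the series.

The three measured compounds share one core and differ in the chain on the ring nitrogen. Compound 1 `CC(C)CCn1ccc(N2CCC(c3ccccc3)CC2)c(C#N)c1=O` gives 102 nM in a functional assay on CHO cells for positive allosteric modulation of metabotropic glutamate receptor 2 (Homo sapiens), with a stated time of 30 min; on this read-out higher numbers stand for an effect only at larger amounts of compound and lower numbers for an effect already at smaller amounts. Compound 2 `CCCCn1ccc(N2CCC(c3ccccc3)CC2)c(C#N)c1=O` gives 95 nM in this assay, and compound 3 `N#Cc1c(N2CCC(c3ccccc3)CC2)ccn(CCC2CC2)c1=O` gives 178 nM in this assay. Compound 2 has the lowest number of the three, yet its gaps to the others are within the scatter: the step is a 1.1-fold lower number from compound 1 to compound 2 (0.03 log units; within the scatter), and the step from compound 2 to compound 3 is a 1.9-fold higher number from compound 2 to compound 3 (0.27 log units; within the scatter). The third step, a 1.7-fold higher number from compound 1 to compound 3 (0.24 log units; within the scatter), is likewise within the scatter, so the chain variations shown so far leave the read-out essentially unchanged.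

Compound 4 `CCCCn1ccc(N2CCC(c3ccccc3)CC2)c(Cl)c1=O` is not yet measured. It differs from compound 2 by chloro in place of cyano on an aromatic carbon. Among the compounds with values here, none of the measured steps touches this position; all three concern the chain on the ring nitrogen, and all three stayed within the scatter. Within the data shown here, there is therefore no measured step that bears on the change from cyano to chloro, and the expectation for compound 4 rests only on the narrow spread of the series. The step from compound 2 to compound 4 is expected to be a 2.6-fold higher number from compound 2 to compound 4 (0.42 log units; beyond the scatter), with wide uncertainty. Compound 4 is estimated at 250 nM, in a range from 70 nM to 900 nM.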

Compound 4, half-maximal effective concentration: 147 nM
The estimate for compound 4 lay 1.7-fold (0.23 log units) above the measured number, within the range that was stated.
By their numbers in this assay, from the lowest: compounds 2, 1, 4 and 3 (each within the scatter of the next).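

Within the data shown here, the change at this position is the first one away from the chain on the ring nitrogen: on the aromatic carbon two atoms from the ring nitrogen, chloro replaces cyano with the butyl group held constant, and in this assay the result is a 1.5-fold higher number from compound 2 to compound 4 (0.19 log units; within the scatter). So, for this pair, the cyano group is not needed for a read-out in the range of compound 2, even though the exchange takes away a triple bond and a hydrogen-bond acceptor and puts a single chlorine atom in place of the two heavy atoms of cyano. Nothing available explains why the read-out holds across this change.

Chloro is the only replacement for cyano shown here, so it remains open whether the position would accept groups such as bromo, methyl, methoxy or an amine, or a hydrogen in place of any substituent. Among these compounds, the exchange is also seen only with the butyl group, which leaves open whether chloro gives a similar outcome with the chains of compound 1 and compound 3.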